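Hydroxy-amide series: microsomal clearance notes on compound 4

The source may hold more compounds than are shown below. What is called first, only, known or untested is meant among the compounds shown, and "the series" means these compounds.

Measured compounds:
compound 1 `O=C(NCc1cc(Cl)ccc1-n1cnnn1)[C@@H]1C[C@@H]2C[C@@H]2N1C(=O)[C@H](O)CC1CC1` — < 12 mL.min-1.g-1
compound 2 `O=C(NCc1cc(Cl)ccc1-n1cnnn1)[C@@H]1C[C@H]2C[C@H]2N1C(=O)[C@H](O)CC1CC1` — 25 mL.min-1.g-1
compound 3 `CC(C)(C)C[C@@H](O)C(=O)N1C[C@@H]2C[C@@H]2[C@H]1C(=O)NCc1cc(Cl)ccc1-n1cnnn1` — 20 mL.min-1.g-1

In an ADME assay on liver for metabolic stability, with Liver microsome (Homo sapiens) as the target, read by LC-MS, using microsomes (a lower number here means slower removal, a higher number faster removal of the compound), compound 1 gives < 12 mL.min-1.g-1, which is a limit of the assay and not a number. Compound 1 thus sits at the low edge of what this set has produced. Compound 2 gives 25 mL.min-1.g-1 and compound 3 gives 20 mL.min-1.g-1. For the measured compounds named here, the only measured step is an at least 2.0-fold higher number from compound 1 to compound 2 (0.31 log units; beyond the scatter), and it rests on (the fact that compounds 1 and 2 differ only in the configuration as drawn), so it says nothing directly about a change of group.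

Compound 4 `COC(C)(C)[C@@H](O)C(=O)N1[C@H](C(=O)NCc2cc(Cl)ccc2-n2cnnn2)C[C@@H]2C[C@@H]21` differs from compound 1 by 1-methoxy-1-methylethyl in place of cyclopropylmethyl on a saturated chain carbon bound to a carbonyl carbon and an oxygen on a saturated carbon. Going by the values given here, no measured step alters this group. Among the compounds with values here, compound 3 carries a different group in the same place and gives 20 mL.min-1.g-1; no step between compound 1 and compound 3 is computed here, so its bearing is indirect. Given (the limit of < 12 mL.min-1.g-1 in this assay, at which 1 of the 3 values shown sits), a modest rise to a reportable number is expected, with a fair chance the limit recurs: an at least 1.2-fold higher number from compound 1 to compound 4 (0.09 log units; that floor lies within the scatter). Compound 4 is therefore expected to give 15 mL.min-1.g-1, within 6 mL.min-1.g-1 to 40 mL.min-1.g-1.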

Compound 4, intrinsic clearance in microsomes: 40 mL.min-1.g-1
Estimate against measurement, compound 4: 2.7-fold (0.43 log units) below; the range from low to high includes it.
By their numbers in this assay, from the lowest: compounds 3, 2 and 4 (each within the scatter of the next). At a limit, below all of these: compound 1.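

In this assay, the place on a saturated chain carbon bound to a carbonyl carbon and an oxygen on a saturated carbon now has its first measured change of group: 1-methoxy-1-methylethyl in place of cyclopropylmethyl gives an at least 3.3-fold higher number from compound 1 to compound 4 (0.52 log units; beyond the scatter). For the compounds shown here, a change at this place alone is therefore enough to move the read-out beyond the scatter, which the only earlier step could not show: the fact that compounds 1 and 2 differ only in the configuration as drawn. On these data alone, compound 1 stands at a limit and not at a number, so the step gives only a floor and its full size stays unknown: the limit of < 12 mL.min-1.g-1 in this assay, at which 1 of the 4 values shown sits.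

Still open, as far as these compounds go, is whether the step goes with the entering oxygen or the lost three-membered ring, and a tert-butyl group in the same place would separate the two. Also open, from the compounds shown here alone, is whether the same change gives a similar step on the core of compound 2.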